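The source may hold more compounds than are shown below. What is called first, only, known or untested is meant among the compounds shown, and "the series" means these compounds.

In an ADME assay on HepG2 cells (Homo sapiens) for cytotoxicity (a lower number here means that less compound is needed, a higher number that more compound is needed for the effect), compound 2 (`Cc1ccc(S(=O)(=O)N[C@@H](CC(=O)NC(C)(C)C)C(=O)NCCNC(=O)c2ccccc2)cc1`) gives > 11000 nM as a limit and not a number. Compound 1 (`Cc1ccc(S(=O)(=O)N[C@@H](CC(=O)NC(C)(C)C)C(=O)NCCNC(=O)c2cc(Cl)ccn2)cc1`) gives > 11000 nM as a limit too. Compound 3 (`Cc1ccc(S(=O)(=O)N[C@@H](CC(=O)NC(C)(C)C)C(=O)NCCNC(=O)Nc2ccccc2)cc1`) likewise gives > 11000 nM as a limit. Among the compounds with values here, compound 2 therefore has no number of its own, and the series so far offers only the limit of > 11000 nM in this assay, at which 3 of the 3 values shown sit, as its evidence.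

The next change leads to compound 4 (`Cc1ccc(S(=O)(=O)N[C@@H](CC(=O)NC(C)(C)C)C(=O)NCCNC(=O)c2ccccc2F)cc1`) and reads fluoro in place of hydrogen on an aromatic carbon as the difference, turning phenyl to 2-fluorophenyl.

The measured steps supply no size for comparison. They are a step that the two limits leave unreadable from compound 1 to compound 2 and a step that the two limits leave unreadable from compound 1 to compound 3 and also a step that the two limits leave unreadable from compound 2 to compound 3 in the same series. None of them places fluoro on an aromatic carbon. With compound 2 at > 11000 nM as a limit, the expectation for this assay is no step beyond the scatter, and another reported limit is the likeliest result.

The step expected is a step that the limit leaves unreadable from compound 2 to compound 4 as an estimate only. Compound 4 is estimated at 14000 nM with an expected range from 8000 nM to 30000 nM in this assay for now.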

Compound 4, half-maximal effective concentration: > 11000 nM
Compound 4: only a limit was reported; the forecaster's own chance of this, stated with the estimate: 85%; the middle value lies beyond the limit too.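

Within the data shown here, compound 4 gives > 11000 nM in this assay, a limit and not a number, so no step between compound 4 and compound 1, compound 2 or compound 3 can be read. Whether phenyl, 4-chloropyridin-2-yl, anilino or 2-fluorophenyl on the carbonyl carbon makes any difference remains open, with a single result across the series: the limit of > 11000 nM in this assay, at which 4 of the 4 values shown sit.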